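Methoxy in place of hydroxy on the shared core

The source may report more compounds than this note shows. Statements on the series, on what has been measured and on what is new or still open speak of the compounds shown alone.

Measured so far:
Compound 1, `COc1cc(Cl)cc(-c2nn(-c3cccc(NC(=O)c4cccc(C(F)(F)F)c4)c3)cc2-c2ccncc2)c1`: 54.6%
Compound 2, `O=C(Nc1cccc(-n2cc(-c3ccncc3)c(-c3cc(O)cc(Cl)c3)n2)c1)c1cc(C(F)(F)F)cc(C(F)(F)F)c1`: 28.9%

Of the compounds shown here, two have been tested in a functional assay on HCC 2998 cells (Homo sapiens) for inhibition, read by sulforhodamine B assay, with a stated time of 48 h, tested at 10 uM; on this read-out higher numbers stand for a weaker effect at the one concentration tested and lower numbers for a stronger effect. Compound 1 gives 54.6%, and compound 2 gives 28.9%, the lowest of the two numbers and thus the stronger effect; the gap between them lies beyond the usual scatter. The two differ in more than one place, so their values alone are what is known.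

Compound 3, `COc1cc(Cl)cc(-c2nn(-c3cccc(NC(=O)c4cc(C(F)(F)F)cc(C(F)(F)F)c4)c3)cc2-c2ccncc2)c1`, has not been measured. It differs from compound 2 in one place: methyl in place of hydrogen on an oxygen on an aromatic ring. In this assay compound 1, which also carries the methoxy group, sits well above compound 2, yet its amide differs as well. For compound 3 a modest step upward from compound 2, toward a weaker effect, is expected, as a number 11.1 percentage points higher from compound 2 to compound 3 (beyond the scatter). The estimate for compound 3 is 40%, within a range of 22% to 62%.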

Compound 3, a percentage reported as activity, at one concentration (the size of the read-out at that concentration, not a potency): 78.3%
The estimate for compound 3 lay 38.3 percentage points below the measured number; measured number above the stated range.
By their numbers in this assay, from the lowest: compound 2; then compound 1; then compound 3.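

Putting a methyl on the oxygen of the 3-chloro-5-hydroxyphenyl group has a large effect in this assay, with a number 49.4 percentage points higher from compound 2 to compound 3 (beyond the scatter), so with this amide the hydroxy form clearly keeps more of the effect than the methoxy form. The earlier pair could not show this, since compound 1 and compound 2 differ in more than one place; the new compound also isolates the amide change, where, with methoxy held constant, the added trifluoromethyl gives a number 23.7 percentage points higher from compound 1 to compound 3 (beyond the scatter), a modest step towards a weaker effect. Nothing available here explains why so small an addition produces so large a step.

Still open, as far as these compounds go, is whether the hydroxy form would also beat the methoxy form on the amide of compound 1. Also open, from the compounds shown here alone, is how an amine in place of the hydroxy, or a longer ethoxy group in place of the methoxy, would compare with compound 2.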